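The compounds below may be only part of what the source reports. "The series", "measured", "known", "first", "only" and "open" are said of these compounds alone.

Measured compounds:
Compound 1, `CSc1nnc(-c2cccc3ccccc23)n1C`. In a functional assay on the whole organism for antagonist activity, with Mus musculus as the target (on this read-out lower numbers stand for an effect already at smaller amounts and higher numbers for an effect only at larger amounts of compound), compound 1 reaches only the limit > 200 mg/kg.
Compound 2, `Cn1c(-c2cccc3ccccc23)nnc1[S+](C)[O-]`. In this assay compound 2 likewise stays at the limit > 200 mg/kg.
Compound 3, `CSc1nnc(-c2ccc(C)cc2)n1C`. In this assay compound 3 stays at the limit > 100 mg/kg.

None of the three values is a number: each is a limit of this assay, as the limit of > 200 mg/kg in this assay, at which 2 of the 3 values shown sit, and the limit of > 100 mg/kg in this assay, at which 1 of the 3 values shown sits, show. From compound 1 to compound 2 the change is a group of 3 heavy atoms (1 carbon, 1 oxygen, 1 sulfur; no ring) in place of a group of 2 heavy atoms (1 carbon, 1 sulfur; no ring), on an aromatic carbon, and the resulting step, a step that the two limits leave unreadable from compound 1 to compound 2, cannot be read because both ends are limits. The difference between the core of compound 1 and the core of compound 3 is not broken down here.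

Compound 4, `Cc1ccc(-c2nnc([S+](C)[O-])n2C)cc1`, is not yet measured in this assay. It differs from compound 3 by a group of 3 heavy atoms (1 carbon, 1 oxygen, 1 sulfur; no ring) in place of a group of 2 heavy atoms (1 carbon, 1 sulfur; no ring), on an aromatic carbon. This is the same kind of change as from compound 1 to compound 2.

The expectation for compound 4 rests on little, because a step that the two limits leave unreadable from compound 1 to compound 2 is unreadable. Compound 3 itself sits at a limit, > 100 mg/kg, so the most probable outcome is that compound 4 also ends at a limit. In this assay compound 4 is expected near 200 mg/kg, in a range from 50 mg/kg to 1000 mg/kg. The expected step is a step that the limit leaves unreadable from compound 3 to compound 4, essentially no change.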

Compound 4, dose for half-maximal effect: > 200 mg/kg
Compound 4 ended at the assay's limit; the forecaster's own chance of this, stated with the estimate: 80%; the middle value lies on the limit itself.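

In this assay compound 3 gives > 100 mg/kg, which is a limit and not a number. Compound 4 gives > 200 mg/kg, also a limit, and no step can be read from compound 3 to compound 4. The compounds shown leave open whether any member of this series gives a numerical half-maximal dose in this assay, and what size the exchange of the methylsulfanyl group has on such a value.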